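Urea-to-amide change at the terminal aryl of the series

The source may report more compounds than this note shows. Statements on the series, on what has been measured and on what is new or still open speak of the compounds shown alone.

Three analogues of the shared core have numbers in a functional assay on OVCAR-8 cells (Homo sapiens) for inhibition, read by sulforhodamine B assay, with a stated time of 48 h, tested at 1 uM (a higher number here means a weaker effect of the compound at the concentration tested, a lower number a stronger effect), so far. Compound 1 `O=C(Nc1cccc(-n2cc(-c3ccncc3)c(-c3cc(O)cc(Cl)c3)n2)c1)Nc1ccc(Cl)c(C(F)(F)F)c1` gives 99% in this assay. Compound 2 `O=C(Nc1cccc(-n2cc(-c3ccncc3)c(-c3cc(O)cc(Cl)c3)n2)c1)Nc1ccc(Cl)c(Cl)c1` gives 56% in this assay, the step of a number 43 percentage points lower from compound 1 to compound 2 (beyond the scatter) being the largest seen. Compound 3 `COc1cc(Cl)cc(-c2nn(-c3cccc(NC(=O)Nc4ccc(Cl)c(Cl)c4)c3)cc2-c2ccncc2)c1` gives 78% in this assay and stands second highest of the three numbers, with the step of a number 22 percentage points higher from compound 2 to compound 3 (beyond the scatter) separating it from its nearer measured neighbour, while compound 1 sits further above it.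

Compound 4 `COc1cc(Cl)cc(-c2nn(-c3cccc(NC(=O)c4cccc(C(F)(F)F)c4)c3)cc2-c2ccncc2)c1` is not yet measured. It differs from compound 3 by 3-(trifluoromethyl)phenyl in place of (3,4-dichlorophenyl)amino on a carbonyl carbon. Among the compounds with values here, no measured step covers a urea turned into an amide, so the only bearing comes from the distal aryl substituent: in the step of a number 43 percentage points lower from compound 1 to compound 2 (beyond the scatter), the trifluoromethyl-bearing compound 1 was the one with the higher number, and compound 4 again carries a trifluoromethyl group on that ring. Within the data shown here, the loss of the amino group between the carbonyl and the distal ring has no precedent in this set.

On that basis compound 4 is expected to move upward, estimated as a number 10 percentage points higher from compound 3 to compound 4 (within the scatter), giving an expected value of 88% with a range from 68% to 102%.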

Compound 4, a percentage reported as activity, at one concentration (the size of the read-out at that concentration, not a potency): 93%
Estimate against measurement, compound 4: 5 percentage points below; measured number inside the range.
By their numbers in this assay, from the lowest: compound 2; then compound 3; then compounds 4 and 1 (each within the scatter of the next).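

Working from the methoxy compound, this assay gives a number 15 percentage points higher from compound 3 to compound 4 (beyond the scatter), so the carbonyl position is sensitive to this exchange, and the higher number means a weaker effect at the concentration tested. The earlier steps shown here changed only a substituent on the terminal aryl or the group on the phenol oxygen, whereas this one alters the link itself, turning the urea into an amide: the leaving (3,4-dichlorophenyl)amino carries 1 hydrogen-bond donor and the entering 3-(trifluoromethyl)phenyl carries 0. No accompanying measurement explains the rise, so the step stands as an observation only.

The step changes the amino group and the aryl substitution together, so the share of each remains unresolved, and a pairing of the amide with the 3,4-dichlorophenyl ring would be needed to separate them. Also open, going by these compounds, is how this position responds to other links on the same carbonyl-bearing arm, such as a sulfonamide or a methylene group in place of the amino group, and whether a terminal morpholine or carboxylic acid on the aryl would shift the number in either direction.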